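The compounds below may be only part of what the source reports. "The series", "measured", "known", "first", "only" and "open" are said of these compounds alone.

Compound 1, `O=C1CS/C(=N\c2csc(-c3ccccc3)c2)N1`, and compound 2, `COc1ccc(/C=C2\S/C(=N\c3csc(-c4ccc(Cl)cc4)c3)NC2=O)cc1`, are the two compounds with measurements.

In a functional assay on MCF7 cells (Homo sapiens) for cytotoxicity, read by MTT assay, with a stated time of 72 h (a lower number here means a stronger inhibitor, a higher number a weaker inhibitor), compound 1 gives > 50000 nM, which is a limit of the assay and not a number. Compound 1 thus sits at the limit of > 50000 nM in this assay, at which 1 of the 2 values shown sits. Within the data shown here, compound 2 gives 1000 nM in this assay, and this is the only number the set holds, so compound 2 stands alone as a measured point.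

Compound 3, `CN(C)c1ccc(/C=C2\S/C(=N\c3csc(-c4ccc(Cl)cc4)c3)NC2=O)cc1`, differs from compound 2 in one place: dimethylamino in place of methoxy on an aromatic carbon. Among the measured compounds shown here, no pair of measured compounds shows what this exchange does in this assay, so there is no measured step to lean on. Given that, the expected step is no change at the digits printed from compound 2 to compound 3 (within the scatter), a change no larger than the usual scatter and in no favoured direction. For compound 3 the estimate in this assay is 1000 nM, with a range from 300 nM to 3500 nM, so that compound 3 is expected to land close to where compound 2 stands.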

Compound 3, half-maximal inhibitory concentration: 400 nM
Estimate against measurement, compound 3: 2.5-fold (0.40 log units) above, and the stated range covers the measured number.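

The set now holds its first measured step, a 2.5-fold lower number from compound 2 to compound 3 (0.40 log units; beyond the scatter), in this assay, on going from 4-methoxyphenyl to 4-(dimethylamino)phenyl. Until now the set held one number and one limit, so it could not show whether a change on this aromatic carbon, para to a large group, moves the read-out at all; this exchange does, even though the two groups have the same counts of hydrogen-bond donors and acceptors, and neither has a ring or a net charge. Nothing measured here accounts for the size or direction of this step.

Only one exchange at this position is shown, so it remains open whether an unsubstituted amine, a hydroxyl or a carboxylic acid in the same place would continue this shift or reverse it. Compound 1 gives > 50000 nM, which is a limit of the assay and not a number, and it differs from compound 2 in more than one place, so the contribution of each difference cannot be read.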